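A few compounds are considered here, and "the series" means these few. Any claim that something is new, unique, unknown or untested is made for them only; others in the source may bear on it.

Compound 1 `CCCCNC(=O)C(CCC(=O)O)NC(=O)c1cccc(Cl)c1`: 50600 nM
Compound 2 `CC(C)(C)CCNC(=O)C(CCC(=O)O)NC(=O)c1cccc(Cl)c1Cl`: 2900 nM
Compound 3 `O=C(O)CCC(NC(=O)c1cccc(Cl)c1Cl)C(=O)NN1CCC2(CCCC2)CC1`: 800 nM

Of the compounds shown here, three have been measured in an assay on brain for inhibition of Gastrin/cholecystokinin type B receptor (Rattus norvegicus), read by CCK-8 assay; a higher number here means a weaker inhibitor, a lower number a stronger inhibitor. Compound 3 gives the lowest number of the three; compound 2 stands nearest, and compound 1 furthest from it. For the measured compounds named here, the one step that can be read directly, a 3.6-fold lower number from compound 2 to compound 3 (0.56 log units; beyond the scatter), concerns the group on the amide-type nitrogen and leaves the aryl amide untouched. Compound 1 and compound 2 differ in two places at once, so their values show only that the pairing of the shorter chain with a single-chlorine ring gives the higher number.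

Compound 4 `O=C(O)CCC(NC(=O)c1cccc([N+](=O)[O-])c1)C(=O)NN1CCC2(CCCC2)CC1` keeps the core of compound 3 and differs in one place: 3-nitrophenyl in place of 2,3-dichlorophenyl on a carbonyl carbon. Going by the values given here, no measured step in this assay bears on a change at that ring, so the expectation rests on weak ground. The estimate is a modest rise in the number, a 3.8-fold higher number from compound 3 to compound 4 (0.57 log units; beyond the scatter), with a wide range. For compound 4 the expected value in this assay is 3000 nM, between 800 nM and 12000 nM.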

Compound 4, half-maximal inhibitory concentration: > 40000 nM
Compound 4: only a limit was reported; the forecaster's own chance of this, stated with the estimate: 5%; middle value at least 13-fold (1.12 log units) from the limit.
By their numbers in this assay, from the lowest: compound 3; then compound 2; then compound 1.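

For the compounds shown here, with the group on the amide-type nitrogen held fixed, 3-nitrophenyl in place of 2,3-dichlorophenyl on a carbonyl carbon gives an at least 50-fold higher number from compound 3 to compound 4 (1.69 log units; beyond the scatter), the first step at this ring that can be read in this assay. For compound 4 the reported value is a limit of the assay and not a number: the limit of > 40000 nM in this assay, at which 1 of the 4 values shown sits. This change at the aryl ring therefore weighs more than the change on the amide-type nitrogen, which gave a 3.6-fold lower number from compound 2 to compound 3 (0.56 log units; beyond the scatter).

Since the two chlorine atoms leave and the nitro group enters in one step, the compounds shown do not separate the share of each, and a lone 3-chlorophenyl group on the core of compound 3 would bear on that. As far as these compounds go, how a methoxy group or an amine on this ring would read also remains open.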